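Branching the acyl chain in ecdysone receptor agonists

The compounds below may be only part of what the source reports. "The series", "measured", "known", "first", "only" and "open" are said of these compounds alone.

Three compounds have been measured in an assay on cells for agonist activity at ecdysone receptor (Bombyx mori), read by a luciferase reporter, with a stated time of 24 h; on this read-out lower numbers stand for an effect already at smaller amounts and higher numbers for an effect only at larger amounts of compound:
compound 1, `CCCCCC(=O)N(NC(=O)c1ccc(CC)cc1)C(C)(C)C`, gives 2820 nM;
compound 2, `CCc1ccc(C(=O)NN(C(=O)CCC(C)C)C(C)(C)C)cc1`, gives 832 nM;
compound 3, `CCCCCC(=O)NN(C(=O)c1cc(C)cc(C)c1)C(C)(C)C`, gives 79.4 nM.

Compound 1 and compound 2 share one core and differ in a single place: isopropyl in place of propyl on a saturated chain carbon, two bonds along the chain from a carbonyl carbon. That change brought a 3.4-fold lower number from compound 1 to compound 2 (0.53 log units; beyond the scatter). Compound 3 is built on another core, and the difference between the core of compound 3 and the core of compound 1 is not broken down here. In this assay compound 3 stands lowest of the three, with compound 2 nearest and compound 1 furthest, both beyond the scatter.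

Compound 4, `Cc1cc(C)cc(C(=O)N(NC(=O)CCC(C)C)C(C)(C)C)c1`, has not yet been measured. It differs from compound 3 by isopropyl in place of propyl on a saturated chain carbon, two bonds along the chain from a carbonyl carbon, the same change, at the same place, as that from compound 1 to compound 2. Compound 4 is expected to show a step of a 3.2-fold lower number from compound 3 to compound 4 (0.50 log units; beyond the scatter) because the same change earlier gave a 3.4-fold lower number from compound 1 to compound 2 (0.53 log units; beyond the scatter). The core of compound 3 has, however, not been tested with this change before, so the range is kept wide. Compound 4 is therefore estimated at 25 nM, between 8 nM and 80 nM.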

Compound 4, half-maximal effective concentration: 91.2 nM
The estimate for compound 4 lay 3.6-fold (0.56 log units) below the measured number; measured number above the stated range.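

In this assay, putting isopropyl in place of propyl on a saturated chain carbon, two bonds along the chain from a carbonyl carbon, did not repeat its earlier effect on the core of compound 3, giving a 1.1-fold higher number from compound 3 to compound 4 (0.06 log units; within the scatter). Set side by side, the two steps on the two cores do not agree: the same change on two cores in this assay, a 3.4-fold lower number (0.53 log units; beyond the scatter) from compound 1 to compound 2 and a 1.1-fold higher number (0.06 log units; within the scatter) from compound 3 to compound 4, 3.9-fold (0.59 log units) apart, beyond the scatter of two such steps. This shows that the step seen on the core of compound 1 cannot be assumed to carry over to another core in this series, but two pairs do not show why the results part or which of them is more typical.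

The compounds shown leave open which part of the difference between the two cores goes with the different steps. As far as these compounds go, it is also open how either core would respond to other changes at the same place, such as a longer chain or a chain ending in an amine or a carboxylic acid.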